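Fluoro-to-chloro exchange in an aryloxyacetamide series

The source may report more compounds than this note shows. Statements on the series, on what has been measured and on what is new or still open speak of the compounds shown alone.

Measured compounds:
compound 1 `Cc1cc(C)cc(NC(=O)COc2cc(C)nc3ccc(F)cc23)c1`, 28000 nM
compound 2 `Cc1cc(C)cc(NC(=O)COc2cc(C)nc3ccc(Cl)cc23)c1`, 8000 nM
compound 3 `COc1ccc2nc(C)cc(OCC(=O)Nc3ccc(F)cc3)c2c1`, 104000 nM

Solubility was read in a physicochemical assay for solubility, in phosphate buffer, measured as kinetic solubility, with a stated time of 1 h, at pH 7.4; on this read-out higher numbers stand for higher solubility and lower numbers for lower solubility. Compound 3 gives the highest number of the three; compound 1 comes nearest, and compound 2 lies furthest away.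

Between compound 1 and compound 2 the only change is chloro in place of fluoro on an aromatic carbon, and this step gave a 3.5-fold lower number from compound 1 to compound 2 (0.54 log units; beyond the scatter).

Compound 4 `COc1ccc2nc(C)cc(OCC(=O)Nc3ccc(Cl)cc3)c2c1` is not yet measured. It differs from compound 3 by chloro in place of fluoro on an aromatic carbon. Going by the values given here, this is the same kind of change as the one from compound 1 to compound 2, but not the same: there the place was on a ring that is part of a fused or bridged system of two rings, meta to a fused ring and para to a fused ring, here it is para to a large group. How the core of compound 3 differs from the core of compound 1 is not broken down here.

In this assay the step from compound 3 to compound 4 is expected to be a 3.2-fold lower number from compound 3 to compound 4 (0.50 log units; beyond the scatter), a size resting on the measured step of a 3.5-fold lower number from compound 1 to compound 2 (0.54 log units; beyond the scatter). Compound 4 is therefore estimated at 33000 nM, between 12000 nM and 90000 nM.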

Compound 4, solubility: 9000 nM
Compound 4: the middle estimate sits 3.7-fold (0.56 log units) above what was measured; the measured number lies below the stated range.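

In this assay, chloro in place of fluoro lowers the number on both cores, with a 12-fold lower number from compound 3 to compound 4 (1.06 log units; beyond the scatter) and, on the core of compound 1, a 3.5-fold lower number from compound 1 to compound 2 (0.54 log units; beyond the scatter), so the direction carries over across these two pairs while the size does not. The two pairs differ both in the core and in the place of the exchange, para to a large group in the 4-fluorophenyl to 4-chlorophenyl step and on a fused ring system in the other, so they do not show whether the core, the place or both set the size of the step. No available measurement bears on why the step is larger on one core than on the other.

The compounds shown leave open how the read-out responds when an amine or a carboxylic acid stands at the para position of the anilide ring instead of a halogen. They also leave open whether bromo continues the fluoro-to-chloro trend on either core.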